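Swapping Methyl for Nitro in Compound 2

The compounds below may be only part of what the source reports. "The series", "measured", "known", "first", "only" and "open" are said of these compounds alone.

Compound 1 `N#C/C(=C\c1ccccc1OS(=O)(=O)c1ccc([N+](=O)[O-])cc1)C(=O)Nc1nnc(Cc2ccccc2)s1` gives 57%
Compound 2 `Cc1ccc(S(=O)(=O)Oc2ccccc2/C=C(\C#N)C(=O)Nc2nnc(Cc3cccc(F)c3)s2)cc1` gives 56%

In a functional assay on RS4-11 cells (Homo sapiens) for inhibition, read by CCK-8 assay, with a stated time of 48 h, tested at 20 uM (on this read-out lower numbers stand for less inhibition of growth and higher numbers for more inhibition of growth at the one concentration tested), compound 2 gives 56% and stands within the usual scatter of compound 1. Compound 3 `N#C/C(=C\c1ccccc1OS(=O)(=O)c1ccc([N+](=O)[O-])cc1)C(=O)Nc1nnc(Cc2cccc(F)c2)s1` alters compound 2 in one place nitro in place of methyl on an aromatic carbon with nitro in place of methyl on an aromatic carbon, turning 4-methylphenyl into 4-nitrophenyl. Going by the values given here, no measured step shows the effect of this swap. With compound 1 at 57% within the scatter of compound 2, no shift beyond the scatter is expected. The expected change is small, an estimated a number 2 percentage points higher from compound 2 to compound 3 (within the scatter) in this assay and no more than scatter. Compound 3 is estimated at 58% with an expected range from 43% to 73% in this test.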

Compound 3, percent growth inhibition at one concentration: 65%
Compound 3: the middle estimate sits 7 percentage points below what was measured, and the stated range covers the measured number.
By their numbers in this assay, from the lowest: compounds 2, 1 and 3 (each within the scatter of the next).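

Changing 4-methylphenyl to 4-nitrophenyl gives a number 9 percentage points higher from compound 2 to compound 3 (within the scatter) in this assay, so at this place on the ring the two groups cannot be told apart. Fluoro in place of hydrogen on an aromatic carbon gives a number 8 percentage points higher from compound 1 to compound 3 (within the scatter), which likewise cannot be told apart from no change. Nothing shown here offers an explanation for these numbers. From the compounds shown here alone, whether an amine or a carboxylic acid at this same place would move the number beyond the scatter remains open.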